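This account rests on a few compounds, and the source may have more. Where it says the series, first, only, none or still open, it means among the compounds named here.

Among the measured compounds shown here, compound 2 `NC(=O)c1cc(-c2ccc(NS(=O)(=O)c3cccc(Cl)c3Cl)cc2)nc2[nH]ncc12` stands second highest of the three numbers so far obtained in an assay for inhibition of serine/threonine-protein kinase Sgk1 (Homo sapiens), with stated times of 30 min and 60 min, in the presence of a further agent that is not named here (a lower number here means a stronger inhibitor, a higher number a weaker inhibitor), where compound 2 gives 236 nM. Compound 1 `CC(C)N1CC[C@H](NC(=O)c2cc(-c3ccc(NS(=O)(=O)c4cccc(Cl)c4Cl)cc3)nc3[nH]ncc23)C1` gives 38 nM in this assay, and compound 3 `CC(C)NC(=O)c1cc(-c2ccc(NS(=O)(=O)c3cccc(Cl)c3Cl)cc2)nc2[nH]ncc12` gives 17600 nM. The unmeasured compound 4 `CN1CC(NC(=O)c2cc(-c3ccc(NS(=O)(=O)c4cccc(Cl)c4Cl)cc3)nc3[nH]ncc23)C1` differs from compound 2 by 1-methylazetidin-3-yl in place of hydrogen on an amide-type nitrogen. For the measured compounds named here, two measured steps bear on this change, both on the same amide-type nitrogen. Taking away the 1-isopropylpyrrolidin-3-yl group gave a 6.2-fold higher number from compound 1 to compound 2 (0.79 log units; beyond the scatter), whereas putting an isopropyl group in place of the hydrogen gave a 75-fold higher number from compound 2 to compound 3 (1.87 log units; beyond the scatter). The group entering in compound 4 is, like the group of compound 1, a ring carrying a nitrogen and joined to the amide nitrogen, and it is unlike the isopropyl of compound 3. Going by the values given here, the change in compound 4 is therefore expected to run toward a lower number in this assay, though with some caution because the only step of this kind rests on compound 1 and is a 6.2-fold higher number from compound 1 to compound 2 (0.79 log units; beyond the scatter). For compound 4 the expected step is a 3.4-fold lower number from compound 2 to compound 4 (0.53 log units; beyond the scatter). Compound 4 is estimated to give 70 nM in this assay, between 20 nM and 250 nM.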

Compound 4, half-maximal inhibitory concentration: < 1 nM
Compound 4 gave a limit, no number (the forecaster's own chance of this, stated with the estimate: 2%); middle value at least 70-fold (1.84 log units) from the limit.
By their numbers in this assay, from the lowest: compound 1; then compound 2; then compound 3. At a limit, below all of these: compound 4.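

In this assay the value of compound 4 is a limit of the assay and not a number: the limit of < 1 nM in this assay, at which 1 of the 4 values shown sits. Among the compounds shown here, the amide-type nitrogen therefore tolerates far more than the earlier compounds showed, with 1-methylazetidin-3-yl giving an at least 230-fold lower number from compound 2 to compound 4 (2.37 log units; beyond the scatter) and an at least 17000-fold lower number from compound 3 to compound 4 (4.24 log units; beyond the scatter), so the choice of group here spans a very wide range. A nitrogen-bearing ring as such does not settle the outcome, as the change of ring group gives an at least 38-fold lower number from compound 1 to compound 4 (1.57 log units; beyond the scatter).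

The compounds shown leave open whether this gain follows the azetidine ring or the methyl on its nitrogen, a question that 1-methylpyrrolidin-3-yl or 1-isopropylazetidin-3-yl would separate. They also leave open how the unsubstituted azetidin-3-yl would compare, and the limit leaves the full size of each step unknown.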